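The source may report more compounds than this note shows. Statements on the series, on what has been measured and on what is new or still open speak of the compounds shown alone.

Compound 1 `O=C1CSC(c2ccc(O)cc2)N1CCN1CCCCC1`: 100%
Compound 2 `Cc1ccc(C2SCC(=O)N2CCN2CCCCC2)cc1`: 100%

In an ADME assay on Vero cells (Chlorocebus sabaeus) for cytotoxicity, read by neutral red uptake, tested at 25 ug/mL (on this read-out lower numbers stand for a stronger effect and higher numbers for a weaker effect at the one concentration tested), compound 1 gives 100%, and compound 2 gives 100%. The step of no change at the digits printed from compound 1 to compound 2 (within the scatter) lies within the scatter, so compound 2 stands level with compound 1 in this assay. Compound 3 `O=C1CSC(c2ccccc2Cl)N1CCN1CCCCC1` has not been measured. It differs from compound 2 by 2-chlorophenyl in place of 4-methylphenyl on a saturated ring carbon. For the measured compounds named here, the single measured step is the only guide here, and it showed nothing beyond the scatter. Compound 3 is therefore expected to stay level, with a step of a number 2 percentage points lower from compound 2 to compound 3 (within the scatter), and its estimated value is 98% between 85% and 100%.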

Compound 3, a percentage reported as activity, at one concentration (the size of the read-out at that concentration, not a potency): 100%
For compound 3 the middle estimate is 2 percentage points below the measured one, and the stated range covers the measured number.
By their numbers in this assay, from the lowest: compounds 1, 2 and 3 (each within the scatter of the next).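

The step to 2-chlorophenyl is no change at the digits printed from compound 2 to compound 3 (within the scatter) in this assay, and the same group set against 4-hydroxyphenyl gives no change at the digits printed from compound 1 to compound 3 (within the scatter) on this saturated ring carbon. The earlier pair exchanged only hydroxy for methyl on an aromatic carbon, whereas here the whole aryl group changes, chlorine enters, and the read-out stays level. Nothing available accounts for this flat result.
Going by these compounds, whether a carboxylic acid on the aromatic ring, or an amine in place of the aryl group, would also stay level remains open. With all three compounds level, these data do not show which part of the structure, if any, can move this read-out.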